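A few compounds are considered here, and "the series" means these few. Any claim that something is new, unique, unknown or untested is made for them only; others in the source may bear on it.

Measured compounds:
- compound 1, `CN(C(=O)CSc1nnc(Cc2nn(C)c(=O)c3ccccc23)n1C)c1ccc(Cl)cc1Cl`: in an assay on isolated protein (Mus musculus) for inhibition of IL15-IL15 receptor (Homo sapiens), read by resazurin assay, with stated times of 30 min and 2.5 days (on this read-out higher numbers stand for weaker inhibition and lower numbers for stronger inhibition), compound 1 gives > 30000 nM, which is a limit of the assay and not a number.
- compound 2, `Cn1c(Cc2nn(C)c(=O)c3ccccc23)nnc1SCC(=O)Nc1ccc(I)cc1`: in this assay compound 2 gives "not active" (no number reported).
- compound 3, `CCCOc1ccc(NC(=O)CSc2nnc(Cc3nn(C)c(=O)c4ccccc34)n2C)cc1`: in this assay compound 3 gives > 30000 nM, again a limit of the assay rather than a number.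

Compound 3 therefore stands nowhere that can be ranked: its value is only a limit, as is that of compound 1, and compound 2 carries no number at all. Among the compounds with values here, the one step among measured compounds that differs in a single place, a step that the two limits leave unreadable from compound 1 to compound 3, is unreadable for the same reason, since both of its ends are limits. Two of the three values sit at the limit of > 30000 nM in this assay, at which 2 of the 3 values shown sit, which is the only firm point of reference in this set.

Compound 4, `CC(C)COc1ccc(NC(=O)CSc2nnc(Cc3nn(C)c(=O)c4ccccc34)n2C)cc1`, is not yet measured. It differs from compound 3 by methyl in place of hydrogen on a saturated chain carbon bound to two saturated chain carbons; cut one bond further out, the change reads propoxy to isobutoxy. Within the data shown here, no measured step bears on this change, and the shared core of compounds 1, 2 and 3 gives no readable number anywhere. Compound 4 is thus expected to stay at the same limit, with an estimated step of a number no higher from compound 3 to compound 4 (the limit leaves the size open). The estimate for compound 4 in this assay is 30000 nM, within a range from 10000 nM to 100000 nM.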

Compound 4, half-maximal inhibitory concentration: 30000 nM
Compound 4: the middle estimate sits on the measured number at the digits printed, and the stated range covers the measured number.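

In this assay compound 4 gives 30000 nM, the first plain number among the compounds shown, so this series now has one value that can be placed on the scale. Compound 3 gives > 30000 nM, which is a limit of the assay and not a number. Methyl in place of hydrogen on a saturated chain carbon bound to two saturated chain carbons, the change of propoxy to isobutoxy, therefore gives a number no higher from compound 3 to compound 4 (the limit leaves the size open), and this shows only that the change brings no readable shift away from the edge of what the assay reports.

As far as these compounds go, it remains open whether any change at this place can move the value clear of the one point at which this set gathers: the limit of > 30000 nM in this assay, at which 2 of the 4 values shown sit. Nor do the compounds shown tell what a longer chain, an amine or a carboxylic acid in place of the isobutoxy group would give in this assay.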